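Hydroxy for Fluoro on the Aryl Arm of Compound 3

The compounds below may be only part of what the source reports. "The series", "measured", "known", "first", "only" and "open" are said of these compounds alone.

Compound 1 `Cc1ccsc1-c1ncnc2c1ncn2C1O[C@H](CO)[C@@H](O)[C@H]1O`: in a functional assay on HeLa cells (Homo sapiens) for inhibition (on this read-out lower numbers stand for stronger inhibition and higher numbers for weaker inhibition), its value is a limit, > 20000 nM.
Compound 2 `OC[C@H]1OC(n2cnc3c(-c4ccc(Cl)cc4)ncnc32)[C@H](O)[C@@H]1O`: 5000 nM.
Compound 3 `OC[C@H]1OC(n2cnc3c(-c4ccc(F)cc4)ncnc32)[C@H](O)[C@@H]1O`: 2700 nM.

Compound 3 and compound 2 sit within the scatter of each other, a 1.9-fold lower number from compound 2 to compound 3 (0.27 log units; within the scatter). The value of compound 1 is the limit of > 20000 nM in this assay, at which 1 of the 3 values shown sits. Compound 4 `OC[C@H]1OC(n2cnc3c(-c4ccc(O)cc4)ncnc32)[C@H](O)[C@@H]1O` carries hydroxy in place of fluoro on an aromatic carbon. Within the data shown here, no measured step swaps a halogen for a hydroxy; the nearest is a 1.9-fold lower number from compound 2 to compound 3 (0.27 log units; within the scatter), which shows that exchanging one halogen for another moves nothing beyond the scatter, while an at least 4.0-fold lower number from compound 1 to compound 2 (0.60 log units; beyond the scatter) and an at least 7.4-fold lower number from compound 1 to compound 3 (0.86 log units; beyond the scatter) concern the ring, not its substituent. Compound 4 is therefore expected near compound 3, a step of a 1.3-fold higher number from compound 3 to compound 4 (0.11 log units; within the scatter), and its estimated value is 3500 nM, between 1200 nM and 12000 nM.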

Compound 4, half-maximal inhibitory concentration: 32500 nM
The estimate for compound 4 lay 9.3-fold (0.97 log units) below the measured number; measured number outside the range, above it.
By their numbers in this assay, from the lowest: compounds 3 and 2 (each within the scatter of the next); then compound 4.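

In this assay, the substituent on the aryl arm proves to matter, which the exchange of one halogen for another had not revealed: hydroxy in place of the halogen gives a 12-fold higher number from compound 3 to compound 4 (1.08 log units; beyond the scatter) and a 6.5-fold higher number from compound 2 to compound 4 (0.81 log units; beyond the scatter). Compound 2 and compound 3 thus remain within the scatter of each other, while compound 4 is clearly weaker than both. The step involving compound 1 cannot be read: the limit of > 20000 nM in this assay, at which 1 of the 4 values shown sits.

Going by these compounds, whether this loss is specific to hydroxy remains open. A methoxy, an amine or a carboxylic acid at this position could separate the hydroxy from other replacements for the halogen.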